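Series notes: the step from compound 3 to compound 4

The source may hold more compounds than are shown below. What is called first, only, known or untested is meant among the compounds shown, and "the series" means these compounds.

In a functional assay on SK-OV-3 cells (Homo sapiens) for cytotoxicity, read by MTT assay, with a stated time of 3 days (on this read-out lower numbers stand for stronger inhibition and higher numbers for weaker inhibition), compound 3 (`N#Cc1c(Nc2nccs2)nc(SCc2nc3ccccc3[nH]2)nc1-c1ccccc1`) gives 5.81 nM. Compound 2 (`N#Cc1c(Nc2ccccc2)nc(SCc2nc3ccccc3[nH]2)nc1-c1ccccc1`) gives 4.46 nM, and a 1.3-fold higher number from compound 2 to compound 3 (0.11 log units; within the scatter) leaves the two within the scatter. Compound 1 (`N#Cc1c(NN)nc(SCc2nc3ccccc3[nH]2)nc1-c1ccccc1`) gives 2.7 nM. The change a 2.2-fold higher number from compound 1 to compound 3 (0.33 log units; beyond the scatter) is modest, while a 1.7-fold higher number from compound 1 to compound 2 (0.22 log units; within the scatter) stays within the scatter.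

Compound 4 (`N#Cc1c(NC(N)=S)nc(SCc2nc3ccccc3[nH]2)nc1-c1ccccc1`) differs from compound 3 on a nitrogen on an aromatic ring: a group of 3 heavy atoms (1 carbon, 1 nitrogen, 1 sulfur; no ring) in place of a group of 5 heavy atoms (3 carbon, 1 nitrogen, 1 sulfur; one five-membered aromatic ring with 2 hetero atoms), on a nitrogen on an aromatic ring. The group that enters has no ring.

All three measured steps exchange the group at this same place, so all three bear on the new step, and none is large. Among the measured compounds shown here, compound 1 is the only measured compound with no ring in this group, and a 2.2-fold higher number from compound 1 to compound 3 (0.33 log units; beyond the scatter) step leads to the one gap beyond the scatter. A small lean toward compound 1 is therefore expected, but no shift beyond the scatter. The expected step is a 1.5-fold lower number from compound 3 to compound 4 (0.16 log units; within the scatter). For compound 4 the estimated value is 4 nM, with an expected range of 1.5 nM to 11 nM.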

Compound 4, half-maximal inhibitory concentration: 7.81 nM
The estimate for compound 4 lay 2.0-fold (0.29 log units) below the measured number; measured number inside the range.
By their numbers in this assay, from the lowest: compounds 1, 2, 3 and 4 (each within the scatter of the next, the first and the last beyond it).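

In this assay the ring on this nitrogen gives way to a ring-free group with no shift beyond the scatter, as a 1.3-fold higher number from compound 3 to compound 4 (0.13 log units; within the scatter) and a 1.8-fold higher number from compound 2 to compound 4 (0.24 log units; within the scatter) both show. Having no ring does not by itself bring a compound to the number of compound 1, since a 2.9-fold higher number from compound 1 to compound 4 (0.46 log units; beyond the scatter) is the widest gap among the four compounds and it separates the two ring-free members. Nothing available accounts for these steps.

Still open, on these data alone, is how a methyl group or a longer alkyl chain on this nitrogen would read, and whether the sulfur of compound 4 matters, which an oxygen in its place would test. Also open, as far as these compounds go, is whether the narrow spread of numbers at this position holds beyond this one cell line.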